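This account rests on a few compounds, and the source may have more. Where it says the series, first, only, none or still open, it means among the compounds named here.

The measured compounds:

Compound 1, `N#Cc1ccc(N2CCC(C(=O)N3N=CC[C@H]3c3cc(F)cc(F)c3)CC2)nn1`: 4.8
Compound 2, `CC(C)(CN)C(=O)N1N=CCC1c1ccccc1`: 1.4
Compound 3, `CC(C)(C)C(=O)N1N=CCC1c1cocn1`: 3

These three compounds were measured in a physicochemical assay for lipophilicity, read by HPLC, measured as chromatographic lipophilicity, at pH 7.4; on this read-out lower numbers stand for lower lipophilicity and higher numbers for higher lipophilicity. Compound 1 gives 4.8, compound 3 gives 3, and compound 2 gives 1.4, the lowest of the three numbers. The nearest of the others to compound 2 is compound 3, whose value stands higher by a gap beyond the scatter; the furthest is compound 1, higher still by a gap well beyond the scatter. None of these pairs differs in only one place, so the three values are simply read side by side without a single change to credit for any of them.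

Compound 4, `O=C(C1CCOCC1)N1N=CCC1c1ccccc1`, has not yet been measured in this assay. It differs from compound 2 in one place, (oxan-4-yl in place of 1-(aminomethyl)-1-methylethyl on a carbonyl carbon). The 1-(aminomethyl)-1-methylethyl group that leaves carries the one hydrogen-bond donor counted there, and the oxan-4-yl group that enters carries none. On this basis the step from compound 2 to compound 4 is expected to be upward and beyond the scatter, namely a number 1.60 log units higher from compound 2 to compound 4 (beyond the scatter). Compound 4 is therefore estimated at 3, within a range from 2.3 to 3.7, close to the value of compound 3 at 3.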

Compound 4, distribution coefficient: 3.1
Compound 4: the middle estimate sits 0.10 log units below what was measured; the range from low to high includes it.
By their numbers in this assay, from the lowest: compound 2; then compounds 3 and 4 (each within the scatter of the next); then compound 1.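

In this assay, for the compounds shown here, oxan-4-yl in place of 1-(aminomethyl)-1-methylethyl, on a carbonyl carbon whose other neighbour is an amide-type nitrogen in a ring, gives a number 1.70 log units higher from compound 2 to compound 4 (beyond the scatter); where the earlier compounds offered no pair differing in one place, this large step ties a change in the read-out to this single position. The counts show that the change is not a simple one: the hydrogen-bond acceptor count stays at 1, while the hydrogen-bond donor count goes from 1 to 0, the heavy-atom count goes from 5 to 6, and an open group gives way to a six-membered non-aromatic ring with 1 hetero atom, so this one step cannot separate these differences from one another. No measurement shown here accounts for the size of the step.

The compounds shown leave open which of these differences carries the step, a question on which a cyclohexyl group or an open-chain ether on the same carbonyl carbon would bear. They also leave open whether the same exchange would give a step of similar size on the core of compound 1 or of compound 3.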